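The compounds below may be only part of what the source reports. "The series", "measured", "known", "first", "only" and "open" are said of these compounds alone.

In an ADME assay on cells (Hepatocyte, Homo sapiens) for metabolic stability, with a stated time of 30 min (a lower number here means that less of the compound is left, a higher number that more of the compound is left), compound 1 (`O=c1cc(N2CCN(CC3CCCCC3)CC2)sc2c(NO)cc(C(F)(F)F)cc12`) gives 19.1% as the higher of the two measured numbers. Compound 2 (`CC(=O)OC1CCC(CN2CCN(c3cc(=O)c4cc(C(F)(F)F)cc([N+](=O)[O-])c4s3)CC2)CC1`) gives 0% as the lowest of them, and its gap to compound 1 lies beyond the scatter. These two compounds differ in more than one place, so no single change between measured compounds can guide what follows. Compound 3 (`COc1ccc(C(=O)OC2CCC(CN3CCN(c4cc(=O)c5cc(C(F)(F)F)cc([N+](=O)[O-])c5s4)CC3)CC2)cc1`) departs from compound 2 in one place, with 4-methoxyphenyl in place of methyl on a carbonyl carbon and the rest of the structure unchanged. Going by the values given here, no measurement yet shows what this change does. Compound 2 at 0% leaves no room for a fall, so any move can only be upward. The expected step of a number 3 percentage points higher from compound 2 to compound 3 (within the scatter) is small, and it is expected to stay within the scatter or only just clear it. In this assay compound 3 is estimated at 3% within an expected range of 0% to 15% for repeated measurements.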

Compound 3, percent of the compound remaining: 12.2%
Compound 3: middle estimate off by 9.2 percentage points, on the low side, and the stated range covers the measured number.
By their numbers in this assay, from the lowest: compound 2; then compounds 3 and 1 (each within the scatter of the next).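

In this assay, going by these compounds alone, putting 4-methoxyphenyl in place of methyl on a carbonyl carbon gives a number 12.2 percentage points higher from compound 2 to compound 3 (beyond the scatter), the first change at a single place that can be read. It shows that this position is not indifferent: with the rest of the structure unchanged, what stands on this carbonyl carbon alters how much of the compound is left, and the larger group gives a higher number than compound 2 at 0%. Nothing at hand explains why the number moves at this position.

The single step changes several things at once, since the entering group brings both a six-membered aromatic ring of carbon only and its methoxy group, so the compounds shown do not separate what each contributes. Going by these compounds, it remains open whether a plain phenyl or a cyclohexyl on this carbonyl carbon would behave like 4-methoxyphenyl, and whether a free hydroxyl or an amine in place of the whole acetoxy group would raise the number further or lower it.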